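A few compounds are considered here, and "the series" means these few. Any claim that something is new, unique, unknown or untested is made for them only; others in the source may bear on it.

Working notes on the series.

Compound 1, `Cc1nnc(-c2cccc(-c3ccc(C(=O)N(Cc4cccc(OCCCCCC(=O)O)c4)C(C)C)cc3)c2)o1`, has only a limit in an ADME assay on BJ cells (Homo sapiens) for cytotoxicity, read by CellTiter-Glo and resazurin assay, with a stated time of 72 h; a higher number here means that more compound is needed for the effect, a lower number that less compound is needed: compound 1 gives > 26000 nM, which is a limit of the assay and not a number. Compound 2, `CCCNCc1ccccc1OCCCCCC(=O)OCC`, also stops at a limit in this assay: compound 2 gives > 26000 nM, again a limit rather than a measured number. So compound 2 stands nowhere in particular among the numbers shown; both values sit at the limit of > 26000 nM in this assay, at which 2 of the 2 values shown sit, and no measured step between compounds is available.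

Compound 3, `CCOC(=O)CCCCCOc1ccccc1C=O`, is not yet measured in this assay. It differs from compound 2 by formyl in place of (propylamino)methyl on an aromatic carbon.

Nothing among the shown compounds points to a change in this assay from such a replacement, so the expected step from compound 2 to compound 3, a step that the limit leaves unreadable from compound 2 to compound 3, is none beyond the scatter, in no particular direction. For compound 3 the estimate in this assay is 30000 nM, with a range from 13000 nM to 70000 nM, and the most likely outcome is once more a limit rather than a number.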

Compound 3, half-maximal effective concentration: > 26000 nM
Compound 3: no number, only a limit (the forecaster's own chance of this, stated with the estimate: 85%); the middle value is on the limit's open side.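

In this assay compound 3 also stops at a limit, so no step can be read between compound 2 and compound 3: the limit of > 26000 nM in this assay, at which 3 of the 3 values shown sit.

The compounds shown leave open whether any of this kind gives a measured number in this assay and whether formyl in place of (propylamino)methyl on an aromatic carbon changes the read-out at all.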